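Swapping an Amide for a Ketone: Expected Growth Inhibition

The compounds below may be only part of what the source reports. "The series", "measured", "known", "first", "only" and "open" are said of these compounds alone.

Compound 1 `N#C/C(=C\N1CCN(C(=O)c2ccco2)C1=S)C(=O)Nc1ccc(Cl)cc1` and compound 2 `N#C/C(=C\N1CCN(C(=O)c2ccco2)C1=S)C(N)=O` share one core and differ only at an amide-type nitrogen. In a functional assay on DU-145 cells (Homo sapiens) for inhibition, read by sulforhodamine B assay, with a stated time of 48 h (on this read-out lower numbers stand for stronger inhibition of growth and higher numbers for weaker inhibition of growth), compound 1 gives 15900 nM, and compound 2 gives 29800 nM, standing at the top of the two numbers shown, a difference that stays within the scatter. Compound 3 `N#C/C(=C\N1CCN(C(=O)c2ccco2)C1=S)C(=O)c1ccccc1` carries phenyl in place of amino on a carbonyl carbon. Within the data shown here, the only measured step bearing on this change is a 1.9-fold higher number from compound 1 to compound 2 (0.27 log units; within the scatter), where an aryl group left without a shift beyond the scatter. Bringing an aryl group back is therefore expected to move this assay by a 1.9-fold lower number from compound 2 to compound 3 (0.27 log units; within the scatter), nothing beyond the scatter. Compound 3 is estimated at 16000 nM, between 5000 nM and 50000 nM.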

Compound 3, concentration for 50% growth inhibition: 5000 nM
Estimate against measurement, compound 3: 3.2-fold (0.51 log units) above; measured number inside the range.
By their numbers in this assay, from the lowest: compound 3; then compounds 1 and 2 (each within the scatter of the next).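

Among these compounds, on the carbonyl carbon, phenyl in place of amino gives a 6.0-fold lower number from compound 2 to compound 3 (0.78 log units; beyond the scatter) in this assay and is the first change here to pass beyond the scatter. Phenyl in place of (4-chlorophenyl)amino gives a 3.2-fold lower number from compound 1 to compound 3 (0.50 log units; beyond the scatter) as well, so an aryl group set directly on the carbonyl carbon reads differently from one set on the amide nitrogen. Nothing available explains this difference.

As far as these compounds go, whether a methyl group or a hydroxyl group on the same carbonyl carbon would give a lower number stays open. So does what a chlorine on the phenyl of compound 3 would do.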